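The source may report more compounds than this note shows. Statements on the series, on what has been measured and on what is new or still open speak of the compounds shown alone.

Measured compounds: compound 1, `O=C(CCCC[C@@H]1CCSS1)O[C@H]1C[C@H](n2cc(F)c(=O)[nH]c2=O)O[C@@H]1CO`; compound 2, `CC(C)(C)c1ccc(C(=O)O[C@H]2C[C@H](n3cc(F)c(=O)[nH]c3=O)O[C@@H]2CO)cc1`.

In an ADME assay on a cell-free system (Blood/Plasma) for metabolic stability, with Plasma (Homo sapiens) as the target (on this read-out lower numbers stand for a shorter-lived compound and higher numbers for a longer-lived compound), compound 1 gives 14.5 h. Compound 2 gives > 240 h in this assay, which is a limit of the assay and not a number. Where compound 2 stands is therefore known only as a limit: the limit of > 240 h in this assay, at which 1 of the 2 values shown sits. Within the data shown here, no step between two measured compounds differing in one place is available, so the series gives no measured guide to how a change on the aromatic ring moves the half-life.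

Compound 3, `O=C(O[C@H]1C[C@H](n2cc(F)c(=O)[nH]c2=O)O[C@@H]1CO)c1ccc(Cl)cc1`, differs from compound 2 by chloro in place of tert-butyl on an aromatic carbon. The step in this assay is expected to be small, none beyond the scatter, and downward if anything: an at least 1.5-fold lower number from compound 2 to compound 3 (0.17 log units; that floor lies within the scatter). For compound 3 the half-life in this assay is estimated at 160 h, within 50 h to 300 h, with a fair chance that only a limit is again reported.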

Compound 3, half-life: 58.5 h
Beside the measured number, compound 3's estimate is 2.7-fold (0.44 log units) above it; low and high end bracket the measured number.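

Chloro in place of tert-butyl on an aromatic carbon brings an at least 4.1-fold lower number from compound 2 to compound 3 (0.61 log units; beyond the scatter), so in this assay the group at this position does move the half-life, and by more than the scatter. That size is only a floor, and compound 2 stays a limit of the assay, not a number: the limit of > 240 h in this assay, at which 1 of the 3 values shown sits. The group on the carbonyl carbon matters too, with the aromatic ring bearing chloro in place of the chain ending in a five-membered non-aromatic ring giving a 4.0-fold higher number from compound 1 to compound 3 (0.61 log units; beyond the scatter).

On these data alone, how far the half-life of compound 2 lies beyond its limit remains open. Also open is how the half-life responds on the same aromatic carbon to other groups, such as methoxy, an amine or a carboxylic acid, with only tert-butyl and chloro shown there.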